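Moving the substituent on the triazole-bound phenyl ring

This account rests on a few compounds, and the source may have more. Where it says the series, first, only, none or still open, it means among the compounds named here.

Compound 2 `Cc1ccc(-n2cc(-c3ccccc3NS(=O)(=O)c3c[nH]c(=O)[nH]c3=O)nn2)cc1` is the shared core carrying a 4-methylphenyl on a ring nitrogen. In a functional assay on OVCAR-3 cells (Homo sapiens) for antiproliferative activity, read by MTT assay, with a stated time of 24 h (a lower number here means a stronger inhibitor, a higher number a weaker inhibitor), compound 2 gives 2190 nM. Within the data shown here, of the two numbers measured so far this is the lower one: its closest neighbour, compound 1 `Cc1ccccc1-n1cc(-c2ccccc2NS(=O)(=O)c2c[nH]c(=O)[nH]c2=O)nn1`, gives 6550 nM in this assay, and the step of a 3.0-fold lower number from compound 1 to compound 2 (0.48 log units; beyond the scatter) exchanges one methylphenyl for another, differing only in where the methyl sits.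

Compound 3 `O=c1[nH]cc(S(=O)(=O)Nc2ccccc2-c2cn(-c3cccc(F)c3)nn2)c(=O)[nH]1` is the next step: 3-fluorophenyl in place of 4-methylphenyl on an aromatic nitrogen. Among the measured compounds shown here, the only measured step that bears on it is a 3.0-fold lower number from compound 1 to compound 2 (0.48 log units; beyond the scatter), which shows that shifting a small group around this ring moves the number by a modest amount. For the measured compounds named here, the change to compound 3 alters both the group and its place, and no measured pair covers a fluorine here, so the direction is open. A modest step in this assay, of about the size already seen, is therefore expected, and the estimate for compound 3 is set at 3000 nM, with a range from 1000 nM to 9000 nM, which means an expected step of a 1.4-fold higher number from compound 2 to compound 3 (0.14 log units; within the scatter).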

Compound 3, half-maximal inhibitory concentration: > 20000 nM
Compound 3: no number, only a limit; the forecaster's own chance of this, stated with the estimate: 5%; at least 6.6-fold (0.82 log units) between middle value and limit.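

Compound 3 gives no number in this assay, only a limit of the assay: the limit of > 20000 nM in this assay, at which 1 of the 3 values shown sits.

The groups that leave and enter have the same count of heavy atoms and each holds one aromatic ring of carbon only, yet this exchange gives an at least 9.1-fold higher number from compound 2 to compound 3 (0.96 log units; beyond the scatter), while moving the methyl gave only a 3.0-fold lower number from compound 1 to compound 2 (0.48 log units; beyond the scatter). The 3-fluorophenyl group also falls short of the weaker methylphenyl compound, with an at least 3.0-fold higher number from compound 1 to compound 3 (0.48 log units; beyond the scatter), so a change on this aromatic nitrogen can cost much more than the first step suggested, and the true size of that cost stays hidden behind the limit.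

Because fluorine replaces methyl and the substituent changes place in the same step, the compounds shown cannot tell which of the two changes matters, or whether both are needed for the loss. From the compounds shown here alone, how an unsubstituted phenyl, or a phenyl carrying an amine or a carboxylic acid, would behave at this position also remains open.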